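Expected paw edema inhibition for a second methoxy analogue

The source may report more compounds than this note shows. Statements on the series, on what has been measured and on what is new or still open speak of the compounds shown alone.

Compound 1 `O=C(N/N=C/c1ccccc1)c1cccnc1Nc1cccc(C(F)(F)F)c1`: 53.9%
Compound 2 `O=C(N/N=C/c1cccc(Cl)c1)c1cccnc1Nc1cccc(C(F)(F)F)c1`: 76.7%
Compound 3 `COc1cccc(/C=N/NC(=O)c2cccnc2Nc2cccc(C(F)(F)F)c2)c1`: 58.8%

Of the compounds shown here, three sharing the core of compound 1 have been tested in a functional assay on the whole organism (strain Wistar) for inhibition, with Rattus norvegicus as the target, read by paw edema, with a stated time of 1 h, at a dose of 10 mg/kg by the intraperitoneal route; on this read-out lower numbers stand for less inhibition and higher numbers for more inhibition at the one dose given (going by the name of the read-out). Compound 1 gives the lowest of the three numbers. Its nearest neighbour is compound 3, where a number 4.9 percentage points higher from compound 1 to compound 3 (within the scatter); its furthest is compound 2, where a number 22.8 percentage points higher from compound 1 to compound 2 (beyond the scatter). Between the two substituted compounds, a number 17.9 percentage points lower from compound 2 to compound 3 (beyond the scatter).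

Compound 4 `COc1ccc(/C=N/NC(=O)c2cccnc2Nc2cccc(C(F)(F)F)c2)cc1` has not yet been measured in this assay. It differs from compound 1 in one place: methoxy in place of hydrogen on an aromatic carbon. Going by the values given here, the step that bears most directly on this change is the one from compound 1 to compound 3, which involved the same entering group, methoxy in place of hydrogen on an aromatic carbon, and stayed within the scatter. The larger step from compound 1 to compound 2 involved chloro instead, so it offers less guidance here. A step within the scatter is therefore expected for compound 4, namely a number 8.1 percentage points higher from compound 1 to compound 4 (within the scatter). Compound 4 is thus estimated at 62%, with a range from 47% to 77%.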

Compound 4, a percentage reported as inhibition, in the whole organism at one dose (the size of the read-out at that dose, not a potency): 59.4%
Compound 4: middle estimate off by 2.6 percentage points, on the high side, and the stated range covers the measured number.
By their numbers in this assay, from the lowest: compounds 1, 3 and 4 (each within the scatter of the next); then compound 2.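

In this assay, methoxy on the aromatic carbon para to a large group gives a number 5.5 percentage points higher from compound 1 to compound 4 (within the scatter) and so, like the 3-methoxyphenyl compound, stays within the scatter of the unsubstituted phenyl. The two methoxy compounds also lie within the scatter of each other, with a number 0.6 percentage points higher from compound 3 to compound 4 (within the scatter) showing that, for this pair, the place of the methoxy group makes no readable difference, while a number 17.3 percentage points lower from compound 2 to compound 4 (beyond the scatter) leaves the 3-chlorophenyl compound apart from both. No measured evidence is available to explain these numbers.

The compounds shown leave open whether chloro on the carbon para to a large group would also stand beyond the scatter from compound 1. They also leave open whether a hydroxyl group or an amine on this ring would stay within the scatter of compound 1.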